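A few compounds are considered here, and "the series" means these few. Any claim that something is new, unique, unknown or untested is made for them only; others in the source may bear on it.

In a functional assay on HeLa cells (Homo sapiens) for cytotoxicity, read by MTT assay, with a stated time of 48 h (a higher number here means a weaker inhibitor, a lower number a stronger inhibitor), compound 1 `CN1CCC(NC(=O)c2ccc(Nc3ncc([N+](=O)[O-])c(NC4CCCC4)n3)cc2)CC1` gives 21700 nM, the highest of the three numbers recorded. Compound 2 `CN1CCN(c2ccc(Nc3ncc(F)c(NC4CCCC4)n3)cc2)CC1` gives 20000 nM in this assay, a number within the scatter of compound 1. Compound 3 `COc1cc(C(=O)NC2CCN(C)CC2)ccc1Nc1ncc(Cl)c(NC2CCCC2)n1` gives 2700 nM in this assay, a number beyond the scatter below compound 1. Among the compounds with values here, no pair of these three compounds differs in a single place, so the values show only that the chloro-bearing compound 3 stands lower than the nitro-bearing compound 1, while the fluoro-bearing compound 2 does not.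

Compound 4 `CN1CCC(NC(=O)c2ccc(Nc3ncc(Br)c(NC4CCCC4)n3)cc2)CC1` has not been measured. Relative to compound 1 it carries bromo in place of nitro on an aromatic carbon, bromo in place of nitro on an aromatic carbon. Because compound 3, which also carries a halogen in place of the nitro, gives 2700 nM, and because compound 2 gives 20000 nM, the halogen is expected to bring at most a modest gain. The expected step is downward and modest, a 2.2-fold lower number from compound 1 to compound 4 (0.34 log units; beyond the scatter), possibly no larger than the scatter. Compound 4 is therefore estimated at 10000 nM in this assay, with a range from 3000 nM to 30000 nM.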

Compound 4, half-maximal inhibitory concentration: 900 nM
For compound 4 the middle estimate is 11-fold (1.05 log units) above the measured one, and the stated range ends above it.
By their numbers in this assay, from the lowest: compound 4; then compound 3; then compounds 2 and 1 (each within the scatter of the next).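

In this assay, nitro gives way to bromo on the aromatic carbon ortho to a cyclopentylamino group, producing a 24-fold lower number from compound 1 to compound 4 (1.38 log units; beyond the scatter) with the rest of the molecule unchanged. Within the data shown here, this is the first direct reading of this position: it shows that a single exchange there, on the core of compound 1, moves the number well beyond the scatter, which no earlier pair could show. Nothing measured on these compounds accounts for the size of this step.

This one pair does not separate a contribution from bromo from one arising from the loss of nitro, and a hydrogen, a methyl group or a nitrile at this position on the same core would bear on that. Also open, from the compounds shown here alone, is whether the step would persist with a cyclohexylamino group in place of the cyclopentylamino group.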